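The source may report more compounds than this note shows. Statements on the series, on what has been measured and on what is new or still open speak of the compounds shown alone.

- Compound 1 `Cc1cc(NC(=O)Nc2cccc(F)c2)c2ccccc2n1` with > 25000 nM
- Compound 2 `Cc1cc(NC(=O)Nc2cccc(N(C)C)c2)c2ccccc2n1` with > 25000 nM

In an ADME assay on Raji cells (Homo sapiens) for cytotoxicity, with a stated time of 72 h (on this read-out higher numbers stand for an effect only at larger amounts of compound and lower numbers for an effect already at smaller amounts), compound 1 gives > 25000 nM as a limit and not a number. Compound 2 gives > 25000 nM as a limit too. For the measured compounds named here, the one measured step is a step that the two limits leave unreadable from compound 1 to compound 2 and it rests on the limit of > 25000 nM in this assay, at which 2 of the 2 values shown sit, and so has no readable size. Compound 3 `Cc1cc(NC(=O)Nc2cc(F)ccc2F)c2ccccc2n1` differs from compound 1 by fluoro in place of hydrogen on an aromatic carbon and so carries fluoro in place of hydrogen on an aromatic carbon. The measured step concerns another change and offers no size to carry over, so in this assay no step beyond the scatter is expected. The estimated step that the limit leaves unreadable from compound 1 to compound 3 is accordingly small. Compound 3 is expected at 30000 nM within an estimated range from 14000 nM to 60000 nM and a limit is expected again.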

Compound 3, half-maximal effective concentration: > 25000 nM
Compound 3 was reported as a limit; the forecaster's own chance of this, stated with the estimate: 85%; the middle value lies beyond the limit too.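

No step can be read from compound 1 to compound 3, since the values of both are limits and not numbers: the limit of > 25000 nM in this assay, at which 3 of the 3 values shown sit. The compounds shown leave open whether fluoro in place of hydrogen changes the read-out at all, and by how much.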